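The source may report more compounds than this note shows. Statements on the series, on what has been measured and on what is new or still open speak of the compounds shown alone.

Measured in a functional assay on MONO-MAC-6 cells (Homo sapiens) for cytotoxicity, read by MTT assay, with a stated time of 24 h; a lower number here means a stronger inhibitor, a higher number a weaker inhibitor:
- compound 1 `O=Cc1ccc(O)c(C(=O)Nc2ccc(C(F)(F)F)cc2)c1`: 21500 nM
- compound 2 `CC(=O)c1ccc(NC(=O)c2cc(Cl)ccc2O)cc1`: 16100 nM
- compound 3 `C/C(=N\OCC(=O)NCC(=O)O)c1ccc(NC(=O)c2cc(Br)ccc2O)cc1`: > 200000 nM

The entry for compound 3 is a limit, not a number.

In this assay, compound 1 at 21500 nM and compound 2 at 16100 nM lie within the scatter of each other. Going by the values given here, compound 1 therefore stands level with compound 2, and these are the only two true numbers in the set.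

The next compound to be read is compound 4 `O=C(Nc1ccc(C(F)(F)F)cc1)c1cc(Br)ccc1O`, which has bromo in place of formyl on an aromatic carbon, para to a hydroxy group (bromo in place of formyl on an aromatic carbon). Among the compounds with values here, no measured pair isolates this exchange, so its size cannot be read from the data and the expectation is only loose. A modest step in this assay is expected, toward a lower number and so a stronger inhibitor, though a result within the scatter would not surprise. The estimated 2.4-fold lower number from compound 1 to compound 4 (0.38 log units; beyond the scatter) reflects this modest expectation. For compound 4, the expected value is 9000 nM, with an estimated range of 3000 nM to 25000 nM.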

Compound 4, half-maximal inhibitory concentration: 2000 nM
Estimate against measurement, compound 4: 4.5-fold (0.65 log units) above; the measured number lies below the stated range.
By their numbers in this assay, from the lowest: compound 4; then compounds 2 and 1 (each within the scatter of the next). At a limit, above all of these: compound 3.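

In this assay, the aromatic carbon para to a hydroxy group proves sensitive to substitution: with the rest of the core of compound 1 held constant, bromo in place of formyl gives an 11-fold lower number from compound 1 to compound 4 (1.03 log units; beyond the scatter), the first single-place comparison available in the series. The exchange replaces two heavy atoms, including a hydrogen-bond acceptor and a double bond outside aromatic rings, with one bromine atom carrying no hydrogen-bond acceptor, so these differences change together in this one pair. No measurement shown explains the size of this step.

With only formyl and bromo compared at this carbon on this core, the data cannot separate a gain from bromo from a loss from removing formyl. An amine, a carboxylic acid or a longer chain at the same position would show how far the trend extends.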